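Adding a Second Chloro to Compound 1

The compounds below may be only part of what the source reports. "The series", "measured", "known", "first", "only" and "open" are said of these compounds alone.

Compound 1, `CN1CCN(c2ccc3[nH]nc(S(=O)(=O)c4ccccc4Cl)c3c2)CC1`: 100%
Compound 2, `CCCn1nc(S(=O)(=O)c2cccc3ccccc23)c2cc(N3CCNCC3)ccc21`: 99%

Of the compounds shown here, two have been measured in a functional assay on HeLa cells for antagonist activity at 5-hydroxytryptamine receptor 6 (Homo sapiens); on this read-out higher numbers stand for larger maximal responses and lower numbers for smaller maximal responses. Compound 1 gives 100%, and compound 2 gives 99%. The two numbers sit within the usual scatter of one another, so neither can be called the larger response; both reach essentially the full response of the reference. Going by the values given here, compound 1 and compound 2 differ in several places at once, so no single structural step links them, and only their two values can be compared.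

Compound 3, `CN1CCN(c2ccc3[nH]nc(S(=O)(=O)c4c(Cl)cccc4Cl)c3c2)CC1`, has not yet been measured in this assay. It comes from compound 1 by one change: chloro in place of hydrogen on an aromatic carbon. Among the compounds with values here, nothing measured so far tells how such a change affects the maximal response, since the only other compound has several differences at once. Compound 1 already reaches the full reference response, and compound 2 does the same despite its different groups, so the step from compound 1 to compound 3 is expected to stay within the scatter: a number 2 percentage points lower from compound 1 to compound 3 (within the scatter). Compound 3 is therefore estimated at 98%, with a range from 85% to 105%.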

Compound 3, largest response reached (reported as Imax), in percent of the reference or control that the assay uses: 100%
Estimate against measurement, compound 3: 2 percentage points below; the measured number falls inside the stated range.
By their numbers in this assay, from the lowest: compounds 2, 1 and 3 (each within the scatter of the next).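

Going by these compounds alone, the first single-place step is chloro in place of hydrogen on an aromatic carbon, turning 2-chlorophenyl into 2,6-dichlorophenyl, and in this assay it gives no change at the digits printed from compound 1 to compound 3 (within the scatter), so a second chloro at this place, ortho to a large group, leaves the maximal response where it was. Compound 1 and compound 3 therefore show that this position of the six-membered aromatic ring can carry a chloro group on both compounds' shared core without any visible loss of the full reference response, something the earlier comparison of compound 1 with compound 2 could not show, as those two differ in several places at once. Nothing shown explains why the response stays the same.

Compound 1 already stands at the full reference response, so this one step cannot tell whether any group at this place could give a larger response. From the compounds shown here alone, whether a group other than chloro, such as methoxy, trifluoromethyl, an amine or a carboxylic acid, would keep the response at this position remains open, as does whether the same chloro change would behave alike on compound 2.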